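This account rests on a few compounds, and the source may have more. Where it says the series, first, only, none or still open, it means among the compounds named here.

Measured in a functional assay on B16-F10 cells (Mus musculus) for antiproliferative activity, read by CCK-8 assay, with a stated time of 48 h; a lower number here means a stronger inhibitor, a higher number a weaker inhibitor:
- compound 1 `COc1ccc(/C=C\c2cc(OC)c(OC)c(OC)c2)cc1OCc1ccc(CNC(C)(C)C(=O)O)cc1`: > 10000 nM
- compound 2 `COc1ccc(/C=C\c2cc(OC)c(OC)c(OC)c2)cc1OCc1ccc(CN2CC(C(=O)O)C2)cc1`: > 10000 nM
- compound 3 `COc1ccc(/C=C\c2cc(OC)c(OC)c(OC)c2)cc1OCc1ccc(CN2CC[C@@H](C(=O)O)C2)cc1`: > 10000 nM

Each of these values is a limit of the assay. Compound 3 therefore has no exact position, and the series as a whole sits at the limit of > 10000 nM in this assay, at which 3 of the 3 values shown sit.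

Compound 4 `COc1ccc(/C=C\c2cc(OC)c(OC)c(OC)c2)cc1OCc1ccc(CN[C@H](C(=O)O)[C@@H](C)O)cc1` carries (1-carboxy-2-hydroxypropyl)amino in place of 3-carboxypyrrolidin-1-yl, on a saturated chain carbon bound to an aromatic carbon: (1-carboxy-2-hydroxypropyl)amino in place of 3-carboxypyrrolidin-1-yl on a saturated chain carbon bound to an aromatic carbon.

The steps bearing on this change are a step that the two limits leave unreadable from compound 1 to compound 3 and a step that the two limits leave unreadable from compound 2 to compound 3. Neither gives a size or a direction. Compound 1 also carries a carboxylated amino group with no ring, (1-carboxy-1-methylethyl)amino, and it gives > 10000 nM, again a limit.

No step beyond the scatter is therefore expected in this assay. The expected step is a step that the limit leaves unreadable from compound 3 to compound 4. Compound 4 is estimated at 20000 nM, with an expected range of 8000 nM to 50000 nM.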

Compound 4, half-maximal inhibitory concentration: 5400 nM
The estimate for compound 4 lay 3.7-fold (0.57 log units) above the measured number; the whole stated range lies above it.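

In this assay, among these compounds, (1-carboxy-2-hydroxypropyl)amino on the saturated chain carbon bound to an aromatic carbon gives the first value that is not a limit. The readable steps are an at least 1.8-fold lower number from compound 3 to compound 4 (0.26 log units; that floor lies within the scatter), an at least 1.8-fold lower number from compound 2 to compound 4 (0.26 log units; that floor lies within the scatter) and an at least 1.8-fold lower number from compound 1 to compound 4 (0.26 log units; that floor lies within the scatter), so none is shown to exceed the scatter, and the steps among the other three compounds cannot be read. Those compounds all remain at a limit: the limit of > 10000 nM in this assay, at which 3 of the 4 values shown sit.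

From the compounds shown here alone, the true size of each step stays open, as does whether the hydroxyl group accounts for it. Going by these compounds, how a methyl ester or a primary amide in place of the carboxylic acid would read in this assay also stays open.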